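Methyl on the bromine-bound chain carbon across two cores

The compounds below may be only part of what the source reports. "The series", "measured", "known", "first", "only" and "open" are said of these compounds alone.

Three compounds of the series are measured. Compound 2 `CNC(=O)NC(=O)c1cccc(NC(=O)CBr)c1` carries the unsubstituted side chain; in a functional assay on CCRF-CEM cells (Homo sapiens) for antiproliferative activity, read by MTT assay, with a stated time of 72 h (a higher number here means a weaker inhibitor, a lower number a stronger inhibitor), compound 2 gives 3160 nM. Compound 1 `CNC(=O)NC(=O)c1cccc(NC(=O)C(C)Br)c1` differs from it by the change (methyl in place of hydrogen on a saturated chain carbon bound to a bromine atom and a carbonyl carbon), and in this assay compound 1 gives 9320 nM. That single change produced a 2.9-fold higher number from compound 2 to compound 1 (0.47 log units; beyond the scatter). Compound 3 `COc1cc(NC(=O)NC(=O)c2cccc(NC(=O)CBr)c2)cc(OC)c1OC` is built on a different core; the difference between the two cores is not broken down here. In this assay compound 3 gives 330 nM, the lowest of the three numbers, and its gap to compound 2 lies beyond the scatter.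

Compound 4 `COc1cc(NC(=O)NC(=O)c2cccc(NC(=O)C(C)Br)c2)cc(OC)c1OC` is not yet measured. It carries the core of compound 3 with the change (methyl in place of hydrogen on a saturated chain carbon bound to a bromine atom and a carbonyl carbon), the same change as in the measured pair, at the same place. Among the compounds with values here, for compound 4 the step in this assay is expected to be about a 2.9-fold higher number from compound 3 to compound 4 (0.46 log units; beyond the scatter), which rests on the single earlier step of a 2.9-fold higher number from compound 2 to compound 1 (0.47 log units; beyond the scatter); with one precedent only, the expectation is uncertain. Compound 4 is estimated at 950 nM, within 450 nM to 2000 nM.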

Compound 4, half-maximal inhibitory concentration: 1330 nM
The estimate for compound 4 lay 1.4-fold (0.15 log units) below the measured number, and the stated range covers the measured number.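

In this assay, methyl in place of hydrogen on the saturated chain carbon bound to a bromine atom and a carbonyl carbon gives a 4.0-fold higher number from compound 3 to compound 4 (0.61 log units; beyond the scatter), so the number rises on the second core as it did on the first. The size of the step also carries over, with no difference between the two cores that can be told from the scatter: the same change on two cores in this assay, a 2.9-fold higher number (0.47 log units; beyond the scatter) from compound 2 to compound 1 and a 4.0-fold higher number (0.61 log units; beyond the scatter) from compound 3 to compound 4, 1.4-fold (0.14 log units) apart, within the scatter of two such steps. This supports transfer of the change between these two cores only, and it shows neither that the step would hold on a third core nor why the number rises.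

Still open, as far as these compounds go, is how a longer chain, such as ethyl on the same chain carbon, would read in this assay. Equally open, from the compounds shown here alone, is what a chlorine atom or an amine in place of the bromine atom would do to the number, and whether the methyl step would stay the same with either group.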